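Removing the sulfanyl side chain from compound 3

The source may hold more compounds than are shown below. What is called first, only, known or untested is meant among the compounds shown, and "the series" means these compounds.

Values in an ADME assay on GES1 cells (Homo sapiens) for inhibition, read by MTT assay, with a stated time of 72 h; a lower number here means a stronger inhibitor, a higher number a weaker inhibitor:
compound 1 `Cc1cc(Nc2cc(-c3ccccc3)[nH]n2)n2nc(SCc3c(Cl)cccc3Cl)nc2n1` gives 39600 nM
compound 2 `Cc1cc(Nc2cc(-c3ccccc3)[nH]n2)n2nc(SCc3ccc(Cl)cc3)nc2n1` gives 31800 nM
compound 3 `Cc1cc(Nc2cc(-c3ccccc3)[nH]n2)n2nc(SCc3nc4ccccc4[nH]3)nc2n1` gives 27800 nM

Compound 3 cannot be separated from the other two on these numbers. The comparisons give a 1.1-fold lower number from compound 2 to compound 3 (0.06 log units; within the scatter) and a 1.4-fold lower number from compound 1 to compound 3 (0.15 log units; within the scatter), while the remaining pair gives a 1.2-fold lower number from compound 1 to compound 2 (0.10 log units; within the scatter).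

The next structure is compound 4 `Cc1cc(Nc2cc(-c3ccccc3)[nH]n2)n2ncnc2n1`. It keeps the shared core and carries hydrogen in place of ((1H-benzimidazol-2-yl)methyl)sulfanyl on an aromatic carbon.

The measured steps bear on this change only in part. Among the measured compounds shown here, each exchanges the group at the end of the sulfanyl chain, and none removes the chain, so no measured compound shows the core without it. The largest of these exchanges is still only a 1.4-fold lower number from compound 1 to compound 3 (0.15 log units; within the scatter), which argues against expecting a large move, although the present change goes further than any of them. A modest shift towards a higher number is expected, not clearly beyond the scatter. In this assay the expected change is a 1.5-fold higher number from compound 3 to compound 4 (0.18 log units; within the scatter). For compound 4 the estimate is 42000 nM, with an expected range from 17000 nM to 100000 nM.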

Compound 4, half-maximal inhibitory concentration: > 50000 nM
Compound 4: only a limit was reported; the forecaster's own chance of this, stated with the estimate: 25%; middle value at least 1.1-fold (0.07 log units) away from the limit.
By their numbers in this assay, from the lowest: compounds 3, 2 and 1 (each within the scatter of the next). At a limit, above all of these: compound 4.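

In this assay compound 4, which carries hydrogen on the aromatic carbon in place of the whole sulfanyl chain, is reported only as a limit, > 50000 nM. Read as floors, the steps are an at least 1.7-fold higher number from compound 3 to compound 4 (0.25 log units; that floor lies within the scatter), an at least 1.5-fold higher number from compound 2 to compound 4 (0.19 log units; that floor lies within the scatter) and an at least 1.2-fold higher number from compound 1 to compound 4 (0.10 log units; that floor lies within the scatter), so the limit does not establish a move beyond the scatter for any of the three pairs. The new information is that compounds 1, 2 and 3, which differ only at the end of the chain, all gave numbers, whereas emptying this position gives no number under the limit, and how far the true value lies past it cannot be told: the limit of > 50000 nM in this assay, at which 1 of the 4 values shown sits.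

The compounds shown leave open how a small group on this carbon, such as methylsulfanyl or an amine, would read in this assay, and so whether the sulfur alone or the ring at the end of the chain goes with a measured number. They also leave open whether a longer chain between the sulfur and that ring would change the reading at all.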